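From chloro to nitro: estimating compound 4

The source may hold more compounds than are shown below. What is called first, only, known or untested is meant among the compounds shown, and "the series" means these compounds.

Values so far in a functional assay on HL-60 cells (Homo sapiens) for cytotoxicity, read by luminescence and CellTiter-Glo, with a stated time of 3 days; a higher number here means a weaker inhibitor, a lower number a stronger inhibitor
Compound 1 `O=C(Nc1ccc(Cl)cc1Cl)c1cc(F)ccc1O` gives 890 nM
Compound 2 `Cc1cccc(O)c1C(=O)Nc1ccc(C#N)cc1` gives 6860 nM
Compound 3 `O=C(Nc1ccc(C(F)(F)F)c(Cl)c1)c1cc(Cl)ccc1O` gives 460 nM

Compound 1 (890 nM) and compound 3 (460 nM) lie within the usual scatter of each other, so the two cannot be ranked. Compound 2 (6860 nM) gives a clearly higher number than compound 1, which marks it as the weaker inhibitor of that pair.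

Compound 4 `O=C(Nc1ccc([N+](=O)[O-])cc1Cl)c1cc(F)ccc1O` is compound 1 with nitro in place of chloro on an aromatic carbon, para to a large group (nitro in place of chloro on an aromatic carbon). Within the data shown here, no two measured compounds differ in one place only, so the data offer no direct guide to this swap. In this assay no step beyond the scatter is expected, although the range is kept wide since compound 2 (6860 nM) shows how far numbers spread in this small set. The step expected by this estimate is a 1.5-fold lower number from compound 1 to compound 4 (0.17 log units; within the scatter) and it stays within the scatter. Compound 4 is expected at 600 nM in a range from 200 nM to 2000 nM once tested.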

Compound 4, half-maximal inhibitory concentration: 280 nM
Compound 4: middle estimate off by 2.1-fold (0.33 log units), on the high side; the range from low to high includes it.
By their numbers in this assay, from the lowest: compounds 4, 3 and 1 (each within the scatter of the next, the first and the last beyond it); then compound 2.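

In this assay, among these compounds, putting nitro in place of chloro on this aromatic carbon, para to a large group, gives a 3.2-fold lower number from compound 1 to compound 4 (0.50 log units; beyond the scatter) and offers the first single-change comparison in this set. The position therefore accepts a larger group without a loss of potency: nitro brings 3 heavy atoms and 2 hydrogen-bond acceptors, where chloro has 1 heavy atom and no hydrogen-bond acceptors. No supporting measurement is available to show which of these differences, if any, accounts for the lower number.

This single step cannot show whether the gain is specific to nitro, and an amine, a carboxylic acid or a methoxy group at the same position could behave quite differently. It also leaves open whether the same swap would lower the number on the core of any other compound.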